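Removing a Fluoro from a Trimethoxy Semicarbazone

The compounds below may be only part of what the source reports. "The series", "measured", "known", "first", "only" and "open" are said of these compounds alone.

Compound 1 `O=C(N/N=C/c1ccc([N+](=O)[O-])cc1)Nc1ccc(Oc2ccnc3[nH]ccc23)c(F)c1` and compound 2 `COc1ccc(/C=N/NC(=O)Nc2ccc(Oc3ccnc4[nH]ccc34)c(F)c2)c(OC)c1OC` share a core; the difference between the two cores is not broken down here. Among the compounds with values here, in a functional assay on MCF7 cells (Homo sapiens) for antiproliferative activity, read by MTT assay, with a stated time of 72 h (a lower number here means a stronger inhibitor, a higher number a weaker inhibitor), compound 1 gives 4000 nM, whereas compound 2 gives 134 nM, the lowest of the three numbers so far. Compound 3 `O=C(N/N=C/c1ccc([N+](=O)[O-])cc1)Nc1ccc(Oc2ccnc3[nH]ccc23)cc1` arises from compound 1 by a single change, (hydrogen in place of fluoro on an aromatic carbon), and in this assay compound 3 gives 15600 nM. That step, a 3.9-fold higher number from compound 1 to compound 3 (0.59 log units; beyond the scatter), is modest but beyond the scatter. Compound 4 `COc1ccc(/C=N/NC(=O)Nc2ccc(Oc3ccnc4[nH]ccc34)cc2)c(OC)c1OC` stands to compound 2 exactly as compound 3 stands to compound 1: the change is hydrogen in place of fluoro on an aromatic carbon, the same change at the same place. The step from compound 2 to compound 4 in this assay is therefore expected to be a 3.9-fold higher number from compound 2 to compound 4 (0.59 log units; beyond the scatter). Within the data shown here, this expectation rests on one precedent only, because a 3.9-fold higher number from compound 1 to compound 3 (0.59 log units; beyond the scatter) is the sole measurement of this change, so the uncertainty is wider than it would be for a change with more than one precedent. Compound 4 is estimated to give 520 nM, with a likely range from 200 nM to 1500 nM.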

Compound 4, half-maximal inhibitory concentration: "not active" (no number reported)
No number was reported for compound 4, so the estimate cannot be set against anything.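

In this assay, within the data shown here, compound 4 is reported only as not active, without a number, so no step from compound 2 to compound 4 can be read. Nothing available here bears on that result. The compounds shown leave open how the size of the change from fluoro to hydrogen compares between the two pairs.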